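Swapping cyclopropyl for tert-butyl on the shared core

This account rests on a few compounds, and the source may have more. Where it says the series, first, only, none or still open, it means among the compounds named here.

Of the compounds shown here, three sharing one core have been measured in a functional assay on CHO-K1 cells for antagonist activity at C-X-C chemokine receptor type 3 (Homo sapiens), read by FLIPR, with a stated time of 10 min; a lower number here means a stronger inhibitor, a higher number a weaker inhibitor. Compound 1 `CCOc1ncc(-c2nc(C(F)(F)F)sc2N2CCN(C(=O)Cn3nc(C)nc3C)[C@H](C)C2)cn1` gives 7 nM. Compound 2 `Cc1nc(C)n(CC(=O)N2CCN(c3sc(C(F)(F)F)nc3-c3cnc(OC4CCC4)nc3)C[C@H]2C)n1` gives 4 nM, and compound 3 `Cc1nc(C)n(CC(=O)N2CCN(c3sc(C(F)(F)F)nc3-c3cnc(C4CC4)nc3)C[C@H]2C)n1` gives 3.5 nM. Compound 3 thus holds the lowest of the three numbers, but its nearest neighbour is compound 2, and the steps of a 1.1-fold lower number from compound 2 to compound 3 (0.06 log units; within the scatter) and a 2.0-fold lower number from compound 1 to compound 3 (0.30 log units; within the scatter) both stay within the scatter, so no order among the three can be claimed. The step of a 1.8-fold lower number from compound 1 to compound 2 (0.24 log units; within the scatter) is likewise within the scatter.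

Compound 4 `Cc1nc(C)n(CC(=O)N2CCN(c3sc(C(F)(F)F)nc3-c3cnc(C(C)(C)C)nc3)C[C@H]2C)n1` differs from compound 3 in one place: tert-butyl in place of cyclopropyl on an aromatic carbon. Going by the values given here, every measured step so far exchanges the group on that same aromatic carbon, and each of them, from ethoxy to cyclobutyloxy, to cyclopropyl, and between the latter two, produced a step that stayed within the scatter. On that evidence the exchange of cyclopropyl for tert-butyl is expected to give no step beyond the scatter, with the estimated change being a 1.3-fold higher number from compound 3 to compound 4 (0.11 log units; within the scatter). Compound 4 is therefore expected to give about 4.5 nM in this assay, with a range from 1.5 nM to 14 nM.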

Compound 4, half-maximal inhibitory concentration: 8.7 nM
For compound 4 the middle estimate is 1.9-fold (0.29 log units) below the measured one; the range from low to high includes it.
By their numbers in this assay, from the lowest: compounds 3, 2, 1 and 4 (each within the scatter of the next, the first and the last beyond it).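

In this assay the position, an aromatic carbon between two ring nitrogen atoms, had so far shown no step beyond the scatter, and tert-butyl is the first group on it to do so, with a 2.5-fold higher number from compound 3 to compound 4 (0.40 log units; beyond the scatter) and a 2.2-fold higher number from compound 2 to compound 4 (0.34 log units; beyond the scatter) as modest steps. The exchange for ethoxy, by contrast, gives a 1.2-fold higher number from compound 1 to compound 4 (0.09 log units; within the scatter) and separates nothing, so tert-butyl parts from cyclopropyl and cyclobutyloxy but not from ethoxy, and the position responds to the group it carries only within a narrow span. Nothing available here speaks to what lies behind this difference between cyclopropyl and tert-butyl.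

The compounds shown leave open how this carbon would read with an amine, a hydroxyl or a carboxylic acid on it, or with a plain methyl or a longer alkyl chain, so the span seen here may not be the full one. They also leave open whether the step from cyclopropyl to tert-butyl would keep its size on a different core, as all four compounds share one.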